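The source may hold more compounds than are shown below. What is called first, only, known or untested is meant among the compounds shown, and "the series" means these compounds.

Working notes on the series

Compound 1 `COc1ccc(/C=C/C(=O)c2ccccc2-c2ccc(OC)c(OC)c2)cc1` and compound 3 `COc1ccc(/C=C/C(=O)c2ccccc2-c2ccc(F)cc2)cc1` share most of their framework, but the difference between the two cores is not broken down here. Among the compounds with values here, in a functional assay on HepG2 cells (Homo sapiens) for antiproliferative activity, read by sulforhodamine B assay, with a stated time of 48 h (on this read-out higher numbers stand for weaker inhibition and lower numbers for stronger inhibition), compound 1 gives 600 nM, and compound 3 gives 93 nM, the lowest number of the three measured so far and beyond the scatter from both others.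

Compound 2 `COc1ccc(/C=C/C(=O)c2ccccc2-c2ccc(OC)c(OC)c2)cc1OC` is compound 1 carrying (methoxy in place of hydrogen on an aromatic carbon). In this assay, within the data shown here, compound 2 gives 3200 nM, so the single change produced a step of a 5.3-fold higher number from compound 1 to compound 2 (0.73 log units; beyond the scatter), a loss of inhibition that is modest but clear.

Compound 4 `COc1ccc(/C=C/C(=O)c2ccccc2-c2ccc(F)cc2)cc1OC` has not yet been measured. It is compound 3 carrying (methoxy in place of hydrogen on an aromatic carbon), the same change as that from compound 1 to compound 2, and the surroundings of the place are described in the same words in both cases. Among the measured compounds shown here, the only precedent for this change is the single pair already measured, and there is no second pair to show whether the size of the step depends on the rest of the molecule.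

For the measured compounds named here, the step of a 4.8-fold higher number from compound 3 to compound 4 (0.68 log units; beyond the scatter) is therefore expected to be of roughly the same size as a 5.3-fold higher number from compound 1 to compound 2 (0.73 log units; beyond the scatter), resting on the one measured instance and on compound 3 starting from 93 nM. On that basis compound 4 is estimated at 450 nM in this assay, with a plausible span from 150 nM to 1500 nM.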

Compound 4, half-maximal inhibitory concentration: 95 nM
The estimate for compound 4 lay 4.7-fold (0.68 log units) above the measured number; measured number below the stated range.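

Methoxy in place of hydrogen on an aromatic carbon does not carry over as a fixed step in this assay: on the core of compound 3 the change gives a 1.0-fold higher number from compound 3 to compound 4 (0.01 log units; within the scatter), whereas on the core of compound 1 it gives a clear loss of inhibition, so the size of the step depends on the rest of the molecule, as the two pairs show: the same change on two cores in this assay, a 5.3-fold higher number (0.73 log units; beyond the scatter) from compound 1 to compound 2 and a 1.0-fold higher number (0.01 log units; within the scatter) from compound 3 to compound 4, 5.2-fold (0.72 log units) apart, beyond the scatter of two such steps

With that same methoxy present on both compounds, 4-fluorophenyl in place of 3,4-dimethoxyphenyl on an aromatic carbon gives a 34-fold lower number from compound 2 to compound 4 (1.53 log units; beyond the scatter), a large step. These pairs do not show what in the two cores sets the steps apart, as the fluorine and the two methoxy groups change together in this swap, and two pairs give no general rule for the series.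

From the compounds shown here alone, it remains open whether the change would leave the number as flat or raise it with a plain phenyl or a monomethoxyphenyl group in place of the 4-fluorophenyl. Also open, going by these compounds, is whether an ethoxy group, a hydroxyl or an amine on the same aromatic carbon would follow either of the two steps.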